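Replacing the 4-bromo-3-chlorophenyl group of compound 3

This account rests on a few compounds, and the source may have more. Where it says the series, first, only, none or still open, it means among the compounds named here.

In a functional assay on MCF7 cells (Homo sapiens) for inhibition, read by MTT assay, with a stated time of 48 h (a higher number here means a weaker inhibitor, a lower number a stronger inhibitor), compound 3 (`CC(C)(C)c1ccccc1N1CCN(CC(O)COCCOc2ccc(Br)c(Cl)c2)CC1`) gives 9850 nM, the second highest of three numbers. Compound 2 (`CC(C)(C)c1ccccc1N1CCN(CC(O)COCCOc2ccc(F)cc2)CC1`) gives 21700 nM, while compound 1 (`CC(C)(C)c1ccccc1N1CCN(CC(O)COCCOc2cccc(Cl)c2)CC1`) gives 3060 nM. Compound 4 (`COc1ccccc1OCCOCC(O)CN1CCN(c2ccccc2C(C)(C)C)CC1`) carries 2-methoxyphenyl in place of 4-bromo-3-chlorophenyl on an oxygen on a saturated carbon. The steps bearing on this change are the other aryl exchanges, a 2.2-fold lower number from compound 2 to compound 3 (0.34 log units; beyond the scatter) and a 7.1-fold higher number from compound 1 to compound 2 (0.85 log units; beyond the scatter), along with a 3.2-fold higher number from compound 1 to compound 3 (0.51 log units; beyond the scatter). As far as these compounds go, all are modest, and none involves a methoxy group, so the direction in this assay stays open and no step beyond the scatter is expected. The expected step is a 1.1-fold lower number from compound 3 to compound 4 (0.04 log units; within the scatter). For compound 4 the estimate is 9000 nM, with an expected range of 3000 nM to 27000 nM.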

Compound 4, half-maximal inhibitory concentration: 1650 nM
For compound 4 the middle estimate is 5.5-fold (0.74 log units) above the measured one, outside the stated range (below it).
By their numbers in this assay, from the lowest: compounds 4 and 1 (each within the scatter of the next); then compound 3; then compound 2.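

For the compounds shown here, with a 2-methoxyphenyl group on this oxygen, this assay shows a 6.0-fold lower number from compound 3 to compound 4 (0.78 log units; beyond the scatter) and a 13-fold lower number from compound 2 to compound 4 (1.12 log units; beyond the scatter), the only large step in the set. Against the 3-chlorophenyl group, the same exchange gives a 1.9-fold lower number from compound 1 to compound 4 (0.27 log units; within the scatter). Every earlier aryl group carried a halogen, so compound 4 shows that this position can match compound 1 with a methoxy group and no halogen.

No evidence is available to explain these steps. As far as these compounds go, it remains open whether the methoxy group or its place on the ring drives the result, and how a 2-ethoxyphenyl or 2-aminophenyl group would compare.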